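Benzyl for Cyclopentyl on the Ring Nitrogen

The source may report more compounds than this note shows. Statements on the series, on what has been measured and on what is new or still open speak of the compounds shown alone.

Measured so far in an assay on cell membranes for displacement of a labelled ligand from Cholecystokinin receptor type A (Rattus norvegicus), read by CCK-8 assay, with a stated time of 2 h; on this read-out higher numbers stand for weaker inhibition and lower numbers for stronger inhibition:
compound 1 `CN1C(=O)C=C(Cl)C1(O)c1ccc(Cl)cc1`: 2000 nM
compound 2 `O=C1C=C(Cl)C(O)(c2ccccc2)N1C1CCCC1`: 360 nM
compound 3 `O=C1C=C(Cl)C(O)(c2ccc(Cl)cc2)N1C1CCCC1`: 2500 nM

Compound 2 gives the lowest number of the three, and both compound 1 and compound 3 lie beyond the scatter above it. The step of a 6.9-fold higher number from compound 2 to compound 3 (0.84 log units; beyond the scatter), chloro in place of hydrogen on an aromatic carbon, is a modest worsening. The step of a 1.3-fold higher number from compound 1 to compound 3 (0.10 log units; within the scatter), cyclopentyl in place of methyl on the amide-type nitrogen in the ring, stays within the scatter.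

Compound 4 `O=C1C=C(Cl)C(O)(c2ccccc2)N1Cc1ccccc1` differs from compound 2 by benzyl in place of cyclopentyl on an amide-type nitrogen in a ring. Among the measured compounds shown here, no measured pair carries benzyl at that place, so the only step that bears on it is a 1.3-fold higher number from compound 1 to compound 3 (0.10 log units; within the scatter), a change at the same nitrogen that did not move the number beyond the scatter. In this assay the step of a 1.1-fold higher number from compound 2 to compound 4 (0.05 log units; within the scatter) is therefore expected to be small, with no clear direction. Compound 4 is estimated at 400 nM, with a range of 120 nM to 1500 nM.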

Compound 4, half-maximal inhibitory concentration: 800 nM
Beside the measured number, compound 4's estimate is 2.0-fold (0.30 log units) below it; the measured number falls inside the stated range.
By their numbers in this assay, from the lowest: compound 2; then compound 4; then compounds 1 and 3 (each within the scatter of the next).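

In this assay, among the compounds shown here, the step of a 2.2-fold higher number from compound 2 to compound 4 (0.35 log units; beyond the scatter), benzyl in place of cyclopentyl, is modest, but it is the first change on the amide-type nitrogen in the ring that lies beyond the scatter, so the number at this position does respond to the group placed there. The earlier step at this nitrogen, a 1.3-fold higher number from compound 1 to compound 3 (0.10 log units; within the scatter), cyclopentyl in place of methyl, stayed within the scatter, and both of its compounds carry a chloro group on the phenyl ring that compound 2 and compound 4 lack. Nothing at hand bears on why the number moves with benzyl.

As far as these compounds go, whether the benzyl step holds with a chloro group on the phenyl ring remains open. Also open, from the compounds shown here alone, is how a longer chain on this nitrogen, such as phenethyl, or a chain ending in an amine or a carboxylic acid, would read.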